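Swapping a Ring Amine on a Shared Propyl Chain

This account rests on a few compounds, and the source may have more. Where it says the series, first, only, none or still open, it means among the compounds named here.

Measured so far:
- compound 1 `COc1cc2c(Oc3ccc(NC(=O)c4cc(-c5ccc(F)cc5)ccn4)cc3F)ccnc2cc1OCCCN1CCCCC1` gives 1370 nM in a functional assay on HT-29 cells (Homo sapiens) for cytotoxicity, read by MTT assay, with a stated time of 72 h; a lower number here means a stronger inhibitor, a higher number a weaker inhibitor
- compound 2 `COc1cc2c(Oc3ccc(NC(=O)c4cc(-c5ccc(F)cc5)ccn4)cc3F)ccnc2cc1OCCCN1CCN(C)CC1` gives 1460 nM in this assay
- compound 3 `COc1cc2c(Oc3ccc(NC(=O)c4nccc(-c5ccc(C)cc5)n4)cc3F)ccnc2cc1OCCCN1CCCCC1` gives 620 nM in this assay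

Compound 1 and compound 2 differ by one change: 4-methylpiperazin-1-yl in place of piperidin-1-yl on a saturated chain carbon, three bonds along the chain from an oxygen on an aromatic ring. That change gave a 1.1-fold higher number from compound 1 to compound 2 (0.03 log units; within the scatter). Compound 3 carries a different core; the difference between the core of compound 1 and the core of compound 3 is not broken down here. Compound 3 shows the lowest number among the three, with compound 1 and compound 2 both beyond the scatter above it.

Compound 4 `COc1cc2c(Oc3ccc(NC(=O)c4nccc(-c5ccc(C)cc5)n4)cc3F)ccnc2cc1OCCCN1CCN(C)CC1` is not yet measured. It relates to compound 3 by the same change: 4-methylpiperazin-1-yl in place of piperidin-1-yl on a saturated chain carbon, three bonds along the chain from an oxygen on an aromatic ring, at the same place as before. Because the earlier step was a 1.1-fold higher number from compound 1 to compound 2 (0.03 log units; within the scatter), the expected step here is a 1.1-fold higher number from compound 3 to compound 4 (0.03 log units; within the scatter), and compound 4 is estimated at 660 nM, likely between 330 nM and 1300 nM.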

Compound 4, half-maximal inhibitory concentration: 210 nM
Compound 4: middle estimate off by 3.1-fold (0.50 log units), on the high side, outside the stated range (below it).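

In this assay, putting 4-methylpiperazin-1-yl in place of piperidin-1-yl gave a 3.0-fold lower number from compound 3 to compound 4 (0.47 log units; beyond the scatter). The same swap therefore did not carry the same result from one core to the other: the same change on two cores in this assay, a 1.1-fold higher number (0.03 log units; within the scatter) from compound 1 to compound 2 and a 3.0-fold lower number (0.47 log units; beyond the scatter) from compound 3 to compound 4, 3.1-fold (0.50 log units) apart, beyond the scatter of two such steps. This shows that the result of the swap on one core was a poor guide to its result on the other, but it does not show which feature of the cores matters, and two pairs set no rule for any further core.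

The compounds shown leave open how a different ring amine, such as morpholin-4-yl, would behave at this place on either core. They also leave open whether a longer chain carrying 4-methylpiperazin-1-yl would keep the same difference between the cores.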